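Chain-linked phenyl versus directly attached aryl on the amine

The source may hold more compounds than are shown below. What is called first, only, known or untested is meant among the compounds shown, and "the series" means these compounds.

Among the measured compounds shown here, compound 2 `COc1ccc(CNC(C)c2cc3c(cc2OC)OC(C)(C)C=C3)cc1` gives 165 nM in an assay on cell membranes for displacement of a labelled ligand from Sigma non-opioid intracellular receptor 1 (Cavia porcellus), read by scintillation counting (a higher number here means a weaker inhibitor, a lower number a stronger inhibitor), the highest of the two numbers measured so far. Compound 1 `COc1cc2c(cc1C(C)NCCCc1ccccc1)C=CC(C)(C)O2` gives 11 nM in this assay. For the measured compounds named here, the only measured step, a 15-fold higher number from compound 1 to compound 2 (1.18 log units; beyond the scatter), shows that swapping the chain-linked phenyl for 4-methoxyphenyl on the chain carbon bound to the amine nitrogen costs a large amount of binding. Compound 3 `COc1cc2c(cc1C(C)NC/C=C/c1ccccc1)C=CC(C)(C)O2` differs from compound 2 in that (2-phenylethenyl in place of 4-methoxyphenyl on a saturated chain carbon bound to an amine nitrogen). Going by the values given here, this restores a phenyl carried on a linker, as in compound 1, but the linker now holds a double bond outside aromatic rings; no measured pair covers that double bond. Because a 15-fold higher number from compound 1 to compound 2 (1.18 log units; beyond the scatter) was large, a large step back toward the number of compound 1 is expected for compound 3, an 8.3-fold lower number from compound 2 to compound 3 (0.92 log units; beyond the scatter). Compound 3 is therefore estimated at 20 nM in this assay, within 6 nM to 70 nM.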

Compound 3, inhibition constant: 83 nM
Beside the measured number, compound 3's estimate is 4.2-fold (0.62 log units) below it, outside the stated range (above it).
By their numbers in this assay, from the lowest: compound 1; then compounds 3 and 2 (each within the scatter of the next).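

In this assay, a phenyl carried on a linker does not by itself recover the binding of compound 1: a 2.0-fold lower number from compound 2 to compound 3 (0.30 log units; within the scatter), so 2-phenylethenyl and 4-methoxyphenyl cannot be told apart on a saturated chain carbon bound to an amine nitrogen. The saturated and unsaturated linkers are not interchangeable at this place, with a 7.5-fold higher number from compound 1 to compound 3 (0.88 log units; beyond the scatter) as 2-phenylethenyl replaces phenethyl. Nothing available accounts for this difference.

Still open, as far as these compounds go, is how the result depends on the length of the chain, which a longer chain such as 4-phenylbutyl would test. Also open, from the compounds shown here alone, is whether a chain carrying an ether oxygen or an amide, or a 4-methoxyphenyl group on the saturated phenethyl chain, would stay close to compound 1 in this series.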